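The source may report more compounds than this note shows. Statements on the series, on what has been measured and on what is new or still open speak of the compounds shown alone.

Measured compounds and their numbers:
compound 1, `[N-]=[N+]=NCc1nnc(-c2cc(S(N)(=O)=O)c(SCc3ccccc3)cc2Cl)o1`: 115000 nM
compound 2, `NCc1nnc(-c2cc(S(N)(=O)=O)c(SCc3ccccc3)cc2Cl)o1`: 490000 nM
compound 3, `NS(=O)(=O)c1cc(-c2nnc(CNC(=O)c3ccccc3)o2)c(Cl)cc1SCc1ccccc1`: 105000 nM

In a functional assay on HeLa cells (Homo sapiens) for cytotoxicity, read by MTT assay, with a stated time of 72 h (a lower number here means a stronger inhibitor, a higher number a weaker inhibitor), compound 1 gives 115000 nM, the second highest of the three numbers; compound 3 sits within the scatter of it, and compound 2 is the furthest away. The step of a 4.3-fold higher number from compound 1 to compound 2 (0.63 log units; beyond the scatter) is a modest one, and the step of a 1.1-fold lower number from compound 1 to compound 3 (0.04 log units; within the scatter) stays within the scatter. Compound 4, `NS(=O)(=O)c1cc(-c2nnc(/C=C/c3ccc(Br)cc3)o2)c(Cl)cc1SCc1ccccc1`, differs from compound 1 in one place: 2-(4-bromophenyl)ethenyl in place of azidomethyl on an aromatic carbon. Among the compounds with values here, no measured step alters this position in the same way; the two steps from compound 1 only exchange the group on the saturated chain carbon, and at most they moved the number modestly, as a 4.3-fold higher number from compound 1 to compound 2 (0.63 log units; beyond the scatter) shows. Compound 4 is therefore expected to stay close to compound 1, with a step of a 1.3-fold lower number from compound 1 to compound 4 (0.11 log units; within the scatter) that is not expected to exceed the scatter by much in either direction. Compound 4 is estimated at 90000 nM, with a range from 30000 nM to 270000 nM.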

Compound 4, half-maximal inhibitory concentration: 29000 nM
The estimate for compound 4 lay 3.1-fold (0.49 log units) above the measured number; measured number outside the range, below it.
By their numbers in this assay, from the lowest: compound 4; then compounds 3 and 1 (each within the scatter of the next); then compound 2.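

In this assay, within the data shown here, the aromatic carbon of the five-membered ring had so far carried only substituted methyl groups, and 2-(4-bromophenyl)ethenyl at this position gives a lower number than all three of them (a 4.0-fold lower number from compound 1 to compound 4 (0.60 log units; beyond the scatter); a 3.6-fold lower number from compound 3 to compound 4 (0.56 log units; beyond the scatter); a 17-fold lower number from compound 2 to compound 4 (1.23 log units; beyond the scatter)). Among these compounds, all three steps lie beyond the scatter, so compound 4 is the strongest inhibitor of the four, and the largest step is the one from the aminomethyl group of compound 2. Nothing available accounts for these steps.

The change brings in the ethenyl link, the phenyl ring and the bromine together, so the compounds shown do not separate their contributions. Going by these compounds, whether the lower number would hold with an unsubstituted 2-phenylethenyl group or a saturated 2-(4-bromophenyl)ethyl group remains open.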